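The compounds below may be only part of what the source reports. "The series", "measured", "known", "first", "only" and "open" are said of these compounds alone.

Three compounds have so far been measured in an in vitro functional assay on HEK293-A cells for antagonist activity at metabotropic glutamate receptor 5 (Rattus norvegicus), read by calcium flux; on this read-out lower numbers stand for stronger inhibition and higher numbers for weaker inhibition:

Compound 1 `Cc1ccccc1NC(=O)c1cc(F)cc(C#N)c1`: > 30000 nM
Compound 2 `Cc1ccc(NC(=O)c2cc(F)cc(C#N)c2)cc1`: > 30000 nM
Compound 3 `COc1ccccc1NC(=O)c1cc(F)cc(C#N)c1`: > 30000 nM

Each of these three values is a limit of the assay and not a number, since all of them sit at the limit of > 30000 nM in this assay, at which 3 of the 3 values shown sit. Compounds 1 and 2 are built from the same atoms joined differently; the difference between their two cores is not broken down here. Compound 3 arises from compound 1 by a single change, (methoxy in place of methyl on an aromatic carbon), and the step it made is a step that the two limits leave unreadable from compound 1 to compound 3.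

Compound 4 `COc1ccc(NC(=O)c2cc(F)cc(C#N)c2)cc1` has not yet been measured. It arises from compound 2 by methoxy in place of methyl on an aromatic carbon. This is the same kind of change as that from compound 1 to compound 3, though not the same: there the methoxy sits ortho to a large group, here para to a large group.

Only limits are known for compound 2, so nothing measured points to a readable step. In this assay compound 4 is expected to give 40000 nM, somewhere between 15000 nM and 120000 nM, most likely again as a limit rather than a number. The expected step is therefore a step that the limit leaves unreadable from compound 2 to compound 4.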

Compound 4, half-maximal inhibitory concentration: > 30000 nM
Compound 4: only a limit was reported; the forecaster's own chance of this, stated with the estimate: 80%; the middle value is on the limit's open side.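

Within the data shown here, compound 2 and compound 4 both give only limits and not numbers, so no step between them can be read, and neither methoxy in place of methyl step has a readable size: the limit of > 30000 nM in this assay, at which 4 of the 4 values shown sit. The compounds shown leave open how strongly any of them inhibits, and which change to the shared core would give a measurable number in this assay.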